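The compounds below may be only part of what the source reports. "The series", "measured", "known", "first", "only" and "open" are said of these compounds alone.

Compounds measured so far:
- compound 1, `COc1cc2c(Oc3ccc(NC(=O)c4cc(-c5ccccc5)ccn4)cc3F)ccnc2cc1OCCCN1CCCC1`, 210 nM
- compound 2, `COc1cc2c(Oc3ccc(NC(=O)c4nccc(-c5ccccc5)n4)cc3F)ccnc2cc1OCCCN1CCCCC1`, 1030 nM
- compound 3, `COc1cc2c(Oc3ccc(NC(=O)c4nccc(-c5ccc(C)cc5)n4)cc3F)ccnc2cc1OCCCN1CCCCC1`, 580 nM

All three were tested in a functional assay on MKN-45 cells (Homo sapiens) for cytotoxicity, read by MTT assay, with a stated time of 72 h; a lower number here means a stronger inhibitor, a higher number a weaker inhibitor. Compound 2 gives the highest of the three numbers: compound 3 is nearest to it, and the step of a 1.8-fold lower number from compound 2 to compound 3 (0.25 log units; within the scatter) is within the scatter; compound 1 is furthest from it, and the gap between compound 2 and compound 1 lies beyond the scatter.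

Compound 4, `COc1cc2c(Oc3ccc(NC(=O)c4nccc(-c5ccccc5)n4)cc3F)ccnc2cc1OCCCN1CCCC1`, has not yet been measured. It differs from compound 2 in one place: pyrrolidin-1-yl in place of piperidin-1-yl on a saturated chain carbon, three bonds along the chain from an oxygen on an aromatic ring.

For the measured compounds named here, no measured pair isolates this exchange. Going by the values given here, the only single step on record, a 1.8-fold lower number from compound 2 to compound 3 (0.25 log units; within the scatter), concerns a methyl on an aromatic carbon and says nothing about the amine ring. Compound 1 carries the pyrrolidin-1-yl group but differs from compound 2 in the amide ring as well, so its lower number cannot be attributed to the amine ring alone. Among the compounds with values here, with no direct precedent, the expected step of a 1.3-fold lower number from compound 2 to compound 4 (0.11 log units; within the scatter) is small, with no direction claimed beyond the scatter. The estimate for compound 4 is therefore 800 nM, within a range from 300 nM to 2200 nM, taken from compound 2 and widened for the lack of a comparable step.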

Compound 4, half-maximal inhibitory concentration: 1360 nM
Compound 4: the middle estimate sits 1.7-fold (0.23 log units) below what was measured; low and high end bracket the measured number.
By their numbers in this assay, from the lowest: compound 1; then compounds 3, 2 and 4 (each within the scatter of the next, the first and the last beyond it).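

In this assay, with the amide ring held constant, pyrrolidin-1-yl in place of piperidin-1-yl at the end of the propyl chain gives a 1.3-fold higher number from compound 2 to compound 4 (0.12 log units; within the scatter), so the two amine rings cannot be told apart at this position on the 4-phenylpyrimidin-2-yl series. For the compounds shown here, with the pyrrolidin-1-yl group held constant, compound 4 also isolates the amide ring for the first time: 4-phenylpyrimidin-2-yl in place of 4-phenylpyridin-2-yl on a carbonyl carbon gives a 6.5-fold higher number from compound 1 to compound 4 (0.81 log units; beyond the scatter), a step that, unlike the amine exchange, lies beyond the scatter. Nothing available on these compounds accounts for either step.

As far as these compounds go, it remains open whether the exchange of piperidin-1-yl for pyrrolidin-1-yl would stay just as small with the 4-phenylpyridin-2-yl amide of compound 1, since the two steps here rest on a single pair each. From the compounds shown here alone, it is also open how this chain position would respond to amines of another kind, such as morpholin-4-yl or dimethylamino, or to a longer chain between the oxygen and the amine.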